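Working notes: replacing 1H-imidazol-2-yl in compound 2

The source may report more compounds than this note shows. Statements on the series, on what has been measured and on what is new or still open speak of the compounds shown alone.

- compound 1 `CN(C)C(=O)c1nc([C@@H](O)[C@H](O)[C@H](O)CO)c[nH]1`: 1740 ng.h/mL
- compound 2 `OC[C@@H](O)[C@@H](O)[C@H](O)c1c[nH]c(-c2ncc[nH]2)n1`: 1500 ng.h/mL

In an ADME assay on the whole organism (plasma, strain 129/SvEvBrd x C57BL/6) for pharmacokinetics, with Mus musculus as the target, at a dose of 10 mg/kg by the oral route (a lower number here means less compound in the circulation, a higher number more compound in the circulation at the dose given), compound 2, at 1500 ng.h/mL, cannot be told apart from compound 1, at 1740 ng.h/mL. Compound 3 `Cn1cnc(-c2nc([C@@H](O)[C@H](O)[C@H](O)CO)c[nH]2)c1` carries 1-methyl-1H-imidazol-4-yl in place of 1H-imidazol-2-yl on an aromatic carbon. Among the compounds with values here, the only measured step on that carbon is a 1.2-fold lower number from compound 1 to compound 2 (0.06 log units; within the scatter), and it stays within the scatter. Within the data shown here, no measured compound carries 1-methyl-1H-imidazol-4-yl, so the evidence is thin, and no step beyond the scatter is expected in this assay. The expected change is a 1.2-fold lower number from compound 2 to compound 3 (0.06 log units; within the scatter). The estimate for compound 3 is 1300 ng.h/mL, with an expected range of 450 ng.h/mL to 3800 ng.h/mL.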

Compound 3, area under the concentration-time curve: 698 ng.h/mL
The estimate for compound 3 lay 1.9-fold (0.27 log units) above the measured number, and the stated range covers the measured number.
By their numbers in this assay, from the lowest: compound 3; then compounds 2 and 1 (each within the scatter of the next).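

In this assay the aromatic carbon between two ring nitrogen atoms now gives a step beyond the scatter, where the earlier pair stayed within it: the change to 1-methyl-1H-imidazol-4-yl gives a 2.1-fold lower number from compound 2 to compound 3 (0.33 log units; beyond the scatter) and, set against dimethylcarbamoyl, it gives a 2.5-fold lower number from compound 1 to compound 3 (0.40 log units; beyond the scatter) as a modest step. This position is therefore not indifferent to the group it carries. Nothing measured here accounts for these steps.

The compounds shown leave open whether the methyl group or the point of attachment of the ring carries the step, and how an amine or a carboxylic acid on this carbon would read.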